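Methyl in Place of Bromo, Tried on a Second Core

The compounds below may be only part of what the source reports. "The series", "measured", "known", "first", "only" and "open" are said of these compounds alone.

Two pairs of compounds share one small change. Compound 3, `O=c1cc(-c2ccccc2)oc2ccc(N3COc4c(Br)cccc4C3)cc12`, carries a bromo group on its outer ring; compound 1, `Cc1cccc2c1OCN(c1ccc3oc(-c4ccccc4)cc(=O)c3c1)C2`, carries a methyl at the same place. In a functional assay on MCF7 cells (Homo sapiens) for inhibition, read by MTT assay, with a stated time of 48 h (a higher number here means a weaker inhibitor, a lower number a stronger inhibitor), compound 3 gives 19600 nM, and compound 1 gives 14300 nM. The change between them is methyl in place of bromo on an aromatic carbon, and the step it made is a 1.4-fold lower number from compound 3 to compound 1 (0.14 log units; within the scatter), so the two values cannot be told apart.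

Compound 2, `O=c1cc(-c2ccccc2)oc2cc(N3COc4c(Br)cccc4C3)ccc12`, is built from the same atoms as compound 3, joined differently; the difference between the two cores is not broken down here. In this assay compound 2 is reported as "not active" (no number reported), with no single number given.

Compound 4, `Cc1cccc2c1OCN(c1ccc3c(=O)cc(-c4ccccc4)oc3c1)C2`, is not yet measured. It stands to compound 2 as compound 1 stands to compound 3: the change is methyl in place of bromo on an aromatic carbon, and the place matches the earlier one word for word, so it is the same change on a different core. Among the measured compounds shown here, since that change left compound 1 and compound 3 within the scatter of each other, a small step is expected from compound 2 to compound 4 in this assay as well, which rests on the single earlier step of a 1.4-fold lower number from compound 3 to compound 1 (0.14 log units; within the scatter) and on compound 2 showing no measurable inhibition. Compound 4 is therefore expected near 35000 nM, most likely between 10000 nM and 120000 nM, with a real chance that only a limit is reported.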

Compound 4, half-maximal inhibitory concentration: 14900 nM
Beside the measured number, compound 4's estimate is 2.3-fold (0.37 log units) above it, and the stated range covers the measured number.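

In this assay, among the compounds shown here, compound 2 is reported as "not active" (no number reported), while compound 4 gives 14900 nM, so no step between these two compounds can be read. The compounds shown leave open how far apart compound 2 and compound 4 lie, and so whether methyl in place of bromo does the same on both cores. No measurement here offers an explanation for these results.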